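A few compounds are considered here, and "the series" means these few. Any claim that something is new, unique, unknown or untested is made for them only; others in the source may bear on it.

Measured in a functional assay on the whole organism with Scenedesmus acutus as the target; on this read-out lower numbers stand for stronger inhibition and higher numbers for weaker inhibition:
- compound 1 `CCCOC(=O)c1cc(N2C(=O)C3=C(CCCC3)C2=O)c(F)cc1Cl` gives 89.1 nM
- compound 2 `CC(C)OC(=O)c1cc(N2C(=O)C3=C(CCCC3)C2=O)ccc1Cl` gives 1000 nM

Compound 2 holds the higher of these two numbers, so it is the weaker inhibitor of the pair, and its gap to compound 1 lies beyond the scatter. Among the compounds with values here, these two compounds differ in more than one place, so the series offers no measured single-change step.

Compound 3 `CC(C)OC(=O)c1cc(N2C(=O)C3=C(CCCC3)C2=O)c(F)cc1Cl` keeps the isopropoxycarbonyl group of compound 2 and has fluoro in place of hydrogen on an aromatic carbon, para to that group (fluoro in place of hydrogen on an aromatic carbon). The expectation rests on compound 1, which also carries the fluoro group and gives 89.1 nM. In this assay the expected step is towards a lower number and beyond the scatter a 13-fold lower number from compound 2 to compound 3 (1.10 log units; beyond the scatter). The estimated value for compound 3 is 80 nM, with an expected range from 25 nM to 260 nM.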

Compound 3, half-maximal inhibitory concentration: 57.5 nM
Beside the measured number, compound 3's estimate is 1.4-fold (0.14 log units) above it, and the stated range covers the measured number.
By their numbers in this assay, from the lowest: compounds 3 and 1 (each within the scatter of the next); then compound 2.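

In this assay, within the data shown here, fluoro in place of hydrogen on this aromatic carbon, para to an isopropoxycarbonyl group, gives a 17-fold lower number from compound 2 to compound 3 (1.24 log units; beyond the scatter), the first single-change reading at this position, and a large one. With fluoro kept, isopropyl in place of propyl on the ester oxygen gives a 1.5-fold lower number from compound 1 to compound 3 (0.19 log units; within the scatter), so this change in the ester chain does not separate the two compounds on this read-out. No supporting data bear on why the fluoro step is this large.

As far as these compounds go, whether a nitrile or a methoxy group on the same aromatic carbon would match fluoro remains open. Also open, from the compounds shown here alone, is how a longer chain such as butyl on the ester oxygen, or a free carboxylic acid in place of the ester, would read in this assay.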